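Sulfonyl substituent changes on the shared core: compound 4

The compounds below may be only part of what the source reports. "The series", "measured", "known", "first", "only" and "open" are said of these compounds alone.

Compound 3 `Cn1c(=O)c(S(=O)(=O)c2ccc(Cl)cc2)cc2cnc(Nc3ccc4[nH]ccc4c3)nc21` carries the lowest number of the three measured in a functional assay on K562 cells (Homo sapiens) for inhibition, read by trypan blue exclusion, with a stated time of 72 h (a lower number here means a stronger inhibitor, a higher number a weaker inhibitor), at 100 nM. Compound 2 `Cn1c(=O)c(S(=O)(=O)c2ccc([N+](=O)[O-])cc2F)cc2cnc(Nc3ccc4[nH]ccc4c3)nc21` gives 200 nM in this assay, and the step of a 2.0-fold lower number from compound 2 to compound 3 (0.30 log units; within the scatter) stays within the scatter. Compound 1 `Cn1c(=O)c(S(=O)(=O)Cc2ccc(F)cc2)cc2cnc(Nc3ccc4[nH]ccc4c3)nc21` gives 30000 nM; the steps of a 150-fold lower number from compound 1 to compound 2 (2.18 log units; beyond the scatter) and a 300-fold lower number from compound 1 to compound 3 (2.48 log units; beyond the scatter) are both large. Compound 4 `Cn1c(=O)c(S(=O)(=O)Nc2ccc(F)cc2F)cc2cnc(Nc3ccc4[nH]ccc4c3)nc21` differs from compound 3 by (2,4-difluorophenyl)amino in place of 4-chlorophenyl on a sulfonyl sulfur. The two steps from compound 1 show that the group on the sulfonyl sulfur moves the number strongly, while a 2.0-fold lower number from compound 2 to compound 3 (0.30 log units; within the scatter) shows that exchanging one substituted phenyl for another barely does. Going by the values given here, no measured step covers a (2,4-difluorophenyl)amino group on the sulfonyl sulfur, so a moderate weakening is expected, a 3.0-fold higher number from compound 3 to compound 4 (0.48 log units; beyond the scatter). Compound 4 is estimated at 300 nM, range 60 nM to 3000 nM.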

Compound 4, half-maximal inhibitory concentration: 5000 nM
Compound 4: middle estimate off by 17-fold (1.22 log units), on the low side; the whole stated range lies below it.
By their numbers in this assay, from the lowest: compounds 3 and 2 (each within the scatter of the next); then compound 4; then compound 1.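

In this assay the (2,4-difluorophenyl)amino group does not behave as one more substituted phenyl on the sulfonyl sulfur, with a 50-fold higher number from compound 3 to compound 4 (1.70 log units; beyond the scatter) and a 25-fold higher number from compound 2 to compound 4 (1.40 log units; beyond the scatter) both large. It still differs from the 4-fluorobenzyl group, with a 6.0-fold lower number from compound 1 to compound 4 (0.78 log units; beyond the scatter) beyond the scatter. Across these four compounds, rings bound directly to the sulfur give the lower numbers and rings linked through the amino nitrogen or benzyl carbon give the higher ones, but no data at hand explain these steps. Still open, on these data alone, is whether the amide hydrogen matters, which a methylamino link would test. Also open, as far as these compounds go, is how a saturated amine such as morpholine on the sulfur would compare.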